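The source may hold more compounds than are shown below. What is called first, only, known or untested is meant among the compounds shown, and "the series" means these compounds.

Three amides built on the same core have been measured. Compound 1 `O=C(Nc1ccc(Cl)cc1)Nc1c(C(O)(C(F)(F)F)C(F)(F)F)ccc2ccccc12` gives 276 nM in an assay on LtK cells with ATP-sensitive inward rectifier potassium channel 11 (Homo sapiens) as the target; a lower number here means that less compound is needed, a higher number that more compound is needed for the effect. Compound 2 `O=C(Nc1c(C(O)(C(F)(F)F)C(F)(F)F)ccc2ccccc12)c1ccccc1` gives 44 nM in this assay, and compound 3 `O=C(Nc1c(C(O)(C(F)(F)F)C(F)(F)F)ccc2ccccc12)c1ccc(Cl)cc1` gives 570 nM in this assay. Compound 3 therefore stands highest of the three numbers; its nearest neighbour is compound 1, reached by a 2.1-fold higher number from compound 1 to compound 3 (0.31 log units; beyond the scatter), and the farthest is compound 2, separated by a 13-fold higher number from compound 2 to compound 3 (1.11 log units; beyond the scatter). Compound 4 `Cc1ccc(C(=O)Nc2c(C(O)(C(F)(F)F)C(F)(F)F)ccc3ccccc23)cc1` differs from compound 3 by methyl in place of chloro on an aromatic carbon. The measured step that bears most directly on this change is a 13-fold higher number from compound 2 to compound 3 (1.11 log units; beyond the scatter), which shows that chloro at this place raised the number sharply relative to hydrogen. Within the data shown here, no measured step shows a methyl at this place, so whether methyl behaves like chloro or like hydrogen remains open. For compound 4 the expected step in this assay is a 2.3-fold lower number from compound 3 to compound 4 (0.36 log units; beyond the scatter), a modest move back toward the number of compound 2. The estimate for compound 4 in this assay is 250 nM, with a range from 70 nM to 900 nM.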

Compound 4, half-maximal effective concentration: 76 nM
Compound 4: the middle estimate sits 3.3-fold (0.52 log units) above what was measured; the measured number falls inside the stated range.
By their numbers in this assay, from the lowest: compounds 2 and 4 (each within the scatter of the next); then compound 1; then compound 3.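

In this assay, the new compound shows that methyl at this aromatic carbon does not follow chloro (a 7.5-fold lower number from compound 3 to compound 4 (0.88 log units; beyond the scatter)) and instead stays level with hydrogen (a 1.7-fold higher number from compound 2 to compound 4 (0.24 log units; within the scatter), within the scatter), so among these three groups the sharp rise at this place belongs to chloro alone. The 4-methylphenyl group on the carbonyl carbon also brings the number down from the (4-chlorophenyl)amino compound (a 3.6-fold lower number from compound 1 to compound 4 (0.56 log units; beyond the scatter)), a direction that the 4-chlorophenyl group did not give. Nothing available here explains why chloro and methyl part in this way.

As far as these compounds go, whether bromo, methoxy, trifluoromethyl, an amine or a carboxylic acid at this place would side with chloro or with methyl remains open. So does whether the methyl result would carry over to a (4-methylphenyl)amino group on the same carbonyl carbon.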